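Thienopyrimidine cytotoxicity: swapping dimethylamino for piperazinyl

The compounds below may be only part of what the source reports. "The series", "measured", "known", "first", "only" and "open" are said of these compounds alone.

The series rests on two arrangements of the same atoms. Compound 1 `CN(C)CC#Cc1cc2ncnc(Nc3ccc(OCc4cccc(F)c4)c(Cl)c3)c2s1` carries a 3-(dimethylamino)prop-1-yn-1-yl chain, and compound 3 `CN(C)CC#Cc1cc2c(Nc3ccc(OCc4cccc(F)c4)c(Cl)c3)ncnc2s1` is built from the same atoms joined differently; the difference between the two cores is not broken down here. Compound 2 `Fc1cccc(COc2ccc(Nc3ncnc4cc(C#CCN5CCNCC5)sc34)cc2Cl)c1` follows from compound 1 through (piperazin-1-yl in place of dimethylamino on a saturated chain carbon bound to a triple-bonded carbon).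

In an ADME assay on HepG2 cells (Homo sapiens) for cytotoxicity (on this read-out higher numbers stand for lower toxicity in this test and lower numbers for higher toxicity in this test), compound 1 reaches only a limit, > 32 uM. In this assay compound 2 likewise gives a limit, > 29 uM. Compound 3 in this assay also stops at a limit, > 32 uM. Two of the three results sit at the limit of > 32 uM in this assay, at which 2 of the 3 values shown sit, and the remaining one at the limit of > 29 uM in this assay, at which 1 of the 3 values shown sits, so the change from compound 1 to compound 2 leaves a step that the two limits leave unreadable from compound 1 to compound 2.

Compound 4 `Fc1cccc(COc2ccc(Nc3ncnc4sc(C#CCN5CCNCC5)cc34)cc2Cl)c1` has not been measured. It arises from compound 3 by piperazin-1-yl in place of dimethylamino on a saturated chain carbon bound to a triple-bonded carbon, the same change that turns compound 1 into compound 2, at the same place. Because the matching change in the measured pair leaves a step that the two limits leave unreadable from compound 1 to compound 2, the step expected in this assay is a step that the limit leaves unreadable from compound 3 to compound 4. For compound 4 in this assay a value of 40 uM is estimated, within a range from 20 uM to 100 uM, and it is expected that the assay will again report only a limit.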

Compound 4, half-maximal toxic concentration: 7.7 uM
Compound 4: middle estimate off by 5.2-fold (0.72 log units), on the high side; the measured number lies below the stated range.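

The piperazin-1-yl change gives an at least 4.1-fold lower number from compound 3 to compound 4 (0.61 log units; beyond the scatter) in this assay, and that step lies beyond the usual scatter, with compound 4 reading a measured 7.7 uM rather than a limit. On the core of compound 1 the matching step cannot be read, as compound 2 also stays at a limit: the limit of > 29 uM in this assay, at which 1 of the 4 values shown sits. The result therefore shows that an unreadable step on one core gave no safe guide to the other, since here the same change ended in a measured number, but it does not show by how much the two cores differ in their response to the change, nor why, and the size of the step on the core of compound 3 is only a minimum, given that its starting point is a limit.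

The compounds shown leave open whether another amine on the same chain, such as morpholin-4-yl, would also come down from the limit on the core of compound 3, or whether this is confined to piperazin-1-yl. They also leave open whether a longer chain carrying the piperazin-1-yl group would give a number similar to that of compound 4 in this assay.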